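This account rests on a few compounds, and the source may have more. Where it says the series, first, only, none or still open, it means among the compounds named here.

Compound 1 `CCC(=O)N(C)c1ccc2[nH]c(-c3n[nH]c4ccccc34)cc2n1`; in a functional assay on KB cells (Homo sapiens) for antiproliferative activity, read by MTT assay, with a stated time of 72 h (on this read-out lower numbers stand for stronger inhibition and higher numbers for weaker inhibition), compound 1 gives 9300 nM.
Compound 2 `CN(C(=O)c1ccc(F)cc1)c1ccc2[nH]c(-c3n[nH]c4ccccc34)cc2n1`; compound 2 gives 7220 nM.
Compound 3 `Cc1ccc(S(=O)(=O)N(C)c2ccc3[nH]c(-c4n[nH]c5ccccc45)cc3n2)cc1`; compound 3 gives 9500 nM.

Compound 3 gives the highest of the three numbers, yet its separation from the others is small: a 1.0-fold higher number from compound 1 to compound 3 (0.01 log units; within the scatter) and a 1.3-fold higher number from compound 2 to compound 3 (0.12 log units; within the scatter). Compound 4 `COc1ccc(OC)c(S(=O)(=O)N(C)c2ccc3[nH]c(-c4n[nH]c5ccccc45)cc3n2)c1` is not yet measured. It differs from compound 3 in one place: 2,5-dimethoxyphenyl in place of 4-methylphenyl on a sulfonyl sulfur. Going by the values given here, of the measured steps, the one from compound 2 to compound 3 is the only one that touches the sulfonyl group, and it exchanges the whole group rather than a substituent on its aryl ring; it stays within the scatter. The other two steps, a 1.3-fold lower number from compound 1 to compound 2 (0.11 log units; within the scatter) and a 1.0-fold higher number from compound 1 to compound 3 (0.01 log units; within the scatter), also stay within the scatter. Nothing measured here varies the substituents on the aryl ring of the sulfonyl, so no step beyond the scatter is expected in this assay. Compound 4 is therefore estimated at 9000 nM, within 4000 nM to 20000 nM, which means an expected step of a 1.1-fold lower number from compound 3 to compound 4 (0.02 log units; within the scatter).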

Compound 4, half-maximal inhibitory concentration: 4380 nM
For compound 4 the middle estimate is 2.1-fold (0.31 log units) above the measured one; the range from low to high includes it.
By their numbers in this assay, from the lowest: compounds 4, 2, 1 and 3 (each within the scatter of the next, the first and the last beyond it).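

The aryl ring on the sulfonyl sulfur turns out to be a place where this assay responds: 2,5-dimethoxyphenyl in place of 4-methylphenyl gives a 2.2-fold lower number from compound 3 to compound 4 (0.34 log units; beyond the scatter). Going by these compounds alone, this modest change is the only step in the set that lies beyond the scatter, whereas the exchanges among propanoyl, (4-fluorophenyl)carbonyl and (4-methylphenyl)sulfonyl on the nitrogen all stayed within it. Nothing available here accounts for the step.

Since the gain rests on this single pair, the compounds shown leave open whether it needs both methoxy groups or whether one would suffice. They also leave open how the number would respond to other groups on this aryl ring, such as an amine or a carboxylic acid.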